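Benzamide thiocarbamates: swapping the piperazine substituent

A few compounds are considered here, and "the series" means these few. Any claim that something is new, unique, unknown or untested is made for them only; others in the source may bear on it.

Of the compounds shown here, three have been measured in a functional assay on HeLa cells (Homo sapiens) for antiproliferative activity, read by CCK-8 assay, with a stated time of 72 h, tested at 8 uM; a higher number here means a stronger effect of the compound at the concentration tested, a lower number a weaker effect. Compound 1 `Nc1ccccc1NC(=O)c1ccc(CSC(=S)N2CCN(Cc3ccncc3)CC2)cc1` gives 72.9% in this assay , which is the highest of the three numbers, though both others sit within the scatter of it. Compound 2 `CN(Cc1ccncc1)C(=S)SCc1ccc(C(=O)Nc2ccccc2N)cc1` gives 72.7% and compound 3 `Nc1ccccc1NC(=O)c1ccc(CSC(=S)N2CCc3cc(Cl)ccc32)cc1` gives 65.1%. Within the data shown here, the one step between compounds that differ in a single place, a number 7.6 percentage points lower from compound 2 to compound 3 (within the scatter), concerns 5-chloro-2,3-dihydro-1H-indol-1-yl in place of methyl((pyridin-4-yl)methyl)amino on a thiocarbonyl carbon.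

Compound 4 `N#Cc1ccc(N2CCN(C(=S)SCc3ccc(C(=O)Nc4ccccc4N)cc3)CC2)cc1`, not yet measured, differs from compound 1 by 4-cyanophenyl in place of (pyridin-4-yl)methyl on an amine nitrogen in a ring. Among the measured compounds shown here, no measured step covers this exchange; the only comparable one, at the amine on the thiocarbonyl, stayed within the scatter. The expectation for compound 4 is therefore a step of a number 2.9 percentage points lower from compound 1 to compound 4 (within the scatter) in this assay , none beyond the scatter. Compound 4 is estimated at 70%, within 55% to 85%.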

Compound 4, a percentage reported as inhibition, at one concentration (the size of the read-out at that concentration, not a potency): 70.6%
Estimate against measurement, compound 4: 0.6 percentage points below; the measured number falls inside the stated range.
By their numbers in this assay, from the lowest: compounds 3, 4, 2 and 1 (each within the scatter of the next).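

At the amine nitrogen in the six-membered ring with two nitrogens, the exchange of (pyridin-4-yl)methyl for 4-cyanophenyl gives a number 2.3 percentage points lower from compound 1 to compound 4 (within the scatter) in this assay. Among these compounds, this is the first step confined to this ring nitrogen, as the earlier step replaced the whole amine on the thiocarbonyl; here a six-membered aromatic ring with a hetero atom gives way to a carbon-only aromatic ring bearing a nitrile, and the two values remain within the scatter of each other. Nothing available speaks to the reason for this result.

As far as these compounds go, whether an acetyl group or a longer alkyl chain on this nitrogen would also stay within the scatter of compound 1 remains open. From the compounds shown here alone, with every compound read at a single concentration, any differences in potency also remain open.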